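Swapping an allyl group for benzoyl on a shared core

A few compounds are considered here, and "the series" means these few. Any claim that something is new, unique, unknown or untested is made for them only; others in the source may bear on it.

Of the compounds shown here, three built on one core have been tested in an ADME assay on L929 cells (Mus musculus) for cytotoxicity, read by resazurin assay, with a stated time of 48 h; on this read-out higher numbers stand for lower toxicity in this test and lower numbers for higher toxicity in this test. Compound 1, `C=CCn1c2ccc([N+](=O)[O-])cc2c(=O)n1Cc1ccccc1`, gives 192000 nM, the second highest of the three numbers. Compound 2, `C#CCn1c2ccc([N+](=O)[O-])cc2c(=O)n1Cc1ccccc1`, gives 195000 nM, and compound 3, `CCOC(=O)n1c2ccc([N+](=O)[O-])cc2c(=O)n1Cc1ccccc1`, gives 122000 nM. The nearest to compound 1 is compound 2, with a 1.0-fold higher number from compound 1 to compound 2 (0.01 log units; within the scatter); the furthest is compound 3, with a 1.6-fold lower number from compound 1 to compound 3 (0.20 log units; within the scatter). Compound 2 and compound 3 lie a 1.6-fold lower number from compound 2 to compound 3 (0.20 log units; within the scatter) apart. All three numbers sit within the usual scatter of one another.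

Compound 4, `O=C(c1ccccc1)n1c2ccc([N+](=O)[O-])cc2c(=O)n1Cc1ccccc1`, has not yet been measured. It differs from compound 1 in one place: benzoyl in place of allyl on an aromatic nitrogen.

Among the measured compounds shown here, the steps that bear on this change are the two in which an ethoxycarbonyl group replaces an allyl or propargyl group on the same aromatic nitrogen, namely a 1.6-fold lower number from compound 1 to compound 3 (0.20 log units; within the scatter) and a 1.6-fold lower number from compound 2 to compound 3 (0.20 log units; within the scatter). Both remained within the scatter. A benzoyl group, like ethoxycarbonyl, attaches through a carbonyl, so a step of similar, small size is expected, perhaps slightly toward a lower number.

Compound 4 is therefore estimated at 130000 nM in this assay, with a likely range from 60000 nM to 260000 nM, which would amount to a step of a 1.5-fold lower number from compound 1 to compound 4 (0.17 log units; within the scatter).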

Compound 4, concentration lethal to 50% of the cells: 146000 nM
Beside the measured number, compound 4's estimate is 1.1-fold (0.05 log units) below it; measured number inside the range.
By their numbers in this assay, from the lowest: compounds 3, 4, 1 and 2 (each within the scatter of the next).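

In this assay, benzoyl on the aromatic nitrogen gives a 1.3-fold lower number from compound 1 to compound 4 (0.12 log units; within the scatter) when it replaces allyl and a 1.3-fold lower number from compound 2 to compound 4 (0.13 log units; within the scatter) when it replaces propargyl, so this position accepts a group with a six-membered aromatic ring, which none of the earlier groups on this nitrogen carried, without a step beyond the scatter. The two groups attached through a carbonyl can also be compared directly: phenyl in place of ethoxy on the carbonyl carbon gives a 1.2-fold higher number from compound 3 to compound 4 (0.08 log units; within the scatter), so the group on that carbon makes no difference that can be told apart in this test. Nothing measured alongside these numbers offers an explanation for this result.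

The compounds shown leave open whether an amine, a carboxylic acid or a longer chain on this nitrogen would also stay within the scatter of compound 1. They also leave open whether the same holds when the benzyl group or the nitro group on the shared core is replaced, since all four compounds carry both unchanged.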